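The source may report more compounds than this note shows. Statements on the series, on what has been measured and on what is new or still open speak of the compounds shown alone.

Compound 3 `COc1cc(Cl)cc(-c2nn(-c3cccc(NC(=O)Nc4ccc(Cl)c(C(F)(F)F)c4)c3)cc2-c2ccncc2)c1` stands at the low end of the three numbers measured in a functional assay on M14 cells (Homo sapiens) for inhibition, read by sulforhodamine B assay, with a stated time of 48 h, tested at 100 uM (on this read-out higher numbers stand for a weaker effect at the one concentration tested and lower numbers for a stronger effect), giving -70%; compound 2 `O=C(Nc1cccc(-n2cc(-c3ccncc3)c(-c3cc(O)cc(Cl)c3)n2)c1)Nc1ccc(Cl)c(Cl)c1` gives -69%, which lies within the scatter of it, while compound 1 `O=C(Nc1cccc(-n2cc(-c3ccncc3)c(-c3cc(O)cc(Cl)c3)n2)c1)Nc1ccc(Cl)c(C(F)(F)F)c1` gives -57%, a gap beyond the scatter. Compound 4 `COc1cc(Cl)cc(-c2nn(-c3cccc(NC(=O)Nc4ccc(Cl)c(Cl)c4)c3)cc2-c2ccncc2)c1` differs from compound 3 by chloro in place of trifluoromethyl on an aromatic carbon. The same change has been seen once already in this assay: a number 12 percentage points lower from compound 1 to compound 2 (beyond the scatter). Among the measured compounds shown here, the other measured step, a number 13 percentage points lower from compound 1 to compound 3 (beyond the scatter), is of like size, so the two changes have not yet been seen together. Compound 4 is expected to show a modest downward step beyond the scatter, a number 10 percentage points lower from compound 3 to compound 4 (within the scatter). The estimate for compound 4 in this assay is -80%, within a range from -95% to -65%.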

Compound 4, a percentage reported as activity, at one concentration (the size of the read-out at that concentration, not a potency): -36%
Estimate against measurement, compound 4: 44 percentage points below; measured number above the stated range.
By their numbers in this assay, from the lowest: compounds 3 and 2 (each within the scatter of the next); then compound 1; then compound 4.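

In this assay, chloro in place of trifluoromethyl gives a number 34 percentage points higher from compound 3 to compound 4 (beyond the scatter) when a methyl sits on the oxygen, so the outcome of this change on the aromatic carbon depends on the group at that oxygen: the same change on two cores in this assay, a number 12 percentage points lower (beyond the scatter) from compound 1 to compound 2 and a number 34 percentage points higher (beyond the scatter) from compound 3 to compound 4, 46 percentage points apart, beyond the scatter of two such steps. Read the other way, methyl in place of hydrogen on the oxygen gives a number 33 percentage points higher from compound 2 to compound 4 (beyond the scatter) when chloro replaces trifluoromethyl, so that change too depends on its partner: the same change on two cores in this assay, a number 13 percentage points lower (beyond the scatter) from compound 1 to compound 3 and a number 33 percentage points higher (beyond the scatter) from compound 2 to compound 4, 46 percentage points apart, beyond the scatter of two such steps. The two changes therefore do not add across these four compounds.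

From the compounds shown here alone, whether this dependence extends to a longer chain on the oxygen, or to a nitrile in place of the chloro or trifluoromethyl, stays open. The compounds shown also leave open how the four would rank at other concentrations.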